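Ring for benzylamino on the shared core

This account rests on a few compounds, and the source may have more. Where it says the series, first, only, none or still open, it means among the compounds named here.

Compound 1 `CC(C(=O)NCc1ccc(C(F)(F)F)nc1NCc1ccccc1)c1ccc(NS(C)(=O)=O)c(F)c1` gives 203 nM in a functional assay on CHO-K1 cells for antagonist activity at transient receptor potential cation channel subfamily V member 1 (Homo sapiens), read by FLIPR; on this read-out lower numbers stand for stronger inhibition and higher numbers for weaker inhibition. That is the higher of the two numbers measured, and its nearest neighbour, compound 2 `Cc1ccc(CC2CCN(c3nc(C(F)(F)F)ccc3CNC(=O)C(C)c3ccc(NS(C)(=O)=O)c(F)c3)CC2)cc1`, gives 17 nM in this assay; the two values lie well apart from each other. Compound 3 `CC(C(=O)NCc1ccc(C(F)(F)F)nc1N1CCCCCCC1)c1ccc(NS(C)(=O)=O)c(F)c1` is not yet measured. It differs from compound 1 in one place: a group of 8 heavy atoms (7 carbon, 1 nitrogen; one eight-membered non-aromatic ring with 1 hetero atom) in place of a group of 8 heavy atoms (7 carbon, 1 nitrogen; one six-membered aromatic ring of carbon only), on an aromatic carbon The group that enters carries no hydrogen-bond donor where the group that leaves carried one, while the count of heavy atoms is unchanged.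

Among the compounds with values here, no step between measured compounds with this change is known. The expectation for the step of a 2.5-fold lower number from compound 1 to compound 3 (0.40 log units; beyond the scatter) is a fall beyond the scatter, though well short of what compound 2 reaches, because compound 2 gives 17 nM in this assay with a quite different group. Compound 3 is estimated at 80 nM, with a range of 20 nM to 320 nM.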

Compound 3, half-maximal inhibitory concentration: 27.8 nM
Estimate against measurement, compound 3: 2.9-fold (0.46 log units) above; the measured number falls inside the stated range.
By their numbers in this assay, from the lowest: compounds 2 and 3 (each within the scatter of the next); then compound 1.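

On the shared core, at the aromatic carbon next to the ring nitrogen, replacing benzylamino with the eight-membered non-aromatic ring gives a 7.3-fold lower number from compound 1 to compound 3 (0.86 log units; beyond the scatter) in this assay. The entering group carries no hydrogen-bond donor, so a donor at this position is not needed for compound 3 at 27.8 nM to lie within the scatter of compound 2 at 17 nM, and this level is reached here without the substituted ring that compound 2 carries. No measurement here accounts for the step.

The change removes the aromatic ring and the hydrogen-bond donor together, and the compounds shown do not separate the two. As far as these compounds go, whether an unsubstituted piperidine or a morpholine at this position would hold such a number also remains open.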